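A Smaller Amine Ring at the End of the Chain

This account rests on a few compounds, and the source may have more. Where it says the series, first, only, none or still open, it means among the compounds named here.

Of the compounds shown here, two built on one shared core have been measured. Compound 1 `COc1ccc(-c2cc(C(=O)Nc3ccc(Oc4ccnc5cc(OCCCN6CCCCC6)c(OC)cc45)c(F)c3)c3ccccc3n2)cc1` gives 210 nM in a functional assay on SMMC-7721 cells (Homo sapiens) for cytotoxicity, read by MTT assay, with a stated time of 72 h; a lower number here means a stronger inhibitor, a higher number a weaker inhibitor. Going by the values given here, compound 2 `COc1cc2c(Oc3ccc(NC(=O)c4cc(-c5ccc(Cl)c(Cl)c5)nc5ccccc45)cc3F)ccnc2cc1OCCCN1CCCCC1` gives 770 nM in this assay, and the only measured step, a 3.7-fold higher number from compound 1 to compound 2 (0.56 log units; beyond the scatter), comes from putting 3,4-dichlorophenyl in place of 4-methoxyphenyl on an aromatic carbon. Among the compounds with values here, compound 2 therefore holds the higher of the two numbers seen so far, with compound 1 as its only neighbour.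

Compound 3 `COc1cc2c(Oc3ccc(NC(=O)c4cc(-c5ccc(Cl)c(Cl)c5)nc5ccccc45)cc3F)ccnc2cc1OCCCN1CCCC1` differs from compound 2 in one place: pyrrolidin-1-yl in place of piperidin-1-yl on a saturated chain carbon, three bonds along the chain from an oxygen on an aromatic ring. Within the data shown here, nothing measured touches this part of the molecule; the single step on record changes the aryl group on the far side of the core and says nothing about the amine ring at the end of the chain. Among the measured compounds shown here, with no step of the same kind to lean on, the expectation is that compound 3 stays close to compound 2, and the expected step of a 1.0-fold higher number from compound 2 to compound 3 (0.02 log units; within the scatter) lies within the scatter. For compound 3 the estimate in this assay is 800 nM, with a range from 300 nM to 2200 nM.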

Compound 3, half-maximal inhibitory concentration: 340 nM
For compound 3 the middle estimate is 2.4-fold (0.37 log units) above the measured one; the measured number falls inside the stated range.
By their numbers in this assay, from the lowest: compounds 1 and 3 (each within the scatter of the next); then compound 2.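

Swapping the six-membered piperidin-1-yl ring at the end of the chain for the five-membered pyrrolidin-1-yl ring gives a 2.3-fold lower number from compound 2 to compound 3 (0.36 log units; beyond the scatter) in this assay, so this far end of the molecule is not a silent part of the structure. The earlier step showed the number moving only with the aryl group on the other side of the core, whereas this one shows that it also responds to a change of a single ring size in the amine, and that this small change is enough to lie beyond the scatter. No measurement available here explains why the smaller ring gives the lower number.

Still open, on these data alone, is how other groups at the end of the chain would read, such as a morpholine ring, an open-chain dimethylamino group or a shorter 2-(pyrrolidin-1-yl)ethyl chain. Also open, as far as these compounds go, is whether the same ring swap gives a similar step when 4-methoxyphenyl replaces 3,4-dichlorophenyl, since this change has so far been read only with the 3,4-dichlorophenyl group in place.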